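Fluorinating the Chain of a Weak Activator

The compounds below may be only part of what the source reports. "The series", "measured", "known", "first", "only" and "open" are said of these compounds alone.

Measured so far:
compound 1, `COC(=O)N(C)c1c(N)nc(-n2nc(Cc3ccccc3F)c3ccccc32)nc1N`: 310 nM
compound 2, `COC(=O)N(C)c1c(N)nc(-n2nc(Cc3c(F)ccc(F)c3F)c3ccccc32)nc1N`: 270 nM
compound 3, `CCCCCc1nn(-c2nc(N)c3c(n2)NC(=O)C3(C)C)c2ccc(Cl)cc12`: 90000 nM

In an assay on CHO cells for activation of soluble guanylate cyclase alpha1/beta1 complex (Homo sapiens), read by cGMP accumulation (on this read-out higher numbers stand for an effect only at larger amounts of compound and lower numbers for an effect already at smaller amounts), compound 3 stands highest of the three numbers, far from compound 1 and compound 2, which sit close to each other. Compound 4, `CC1(C)C(=O)Nc2nc(-n3nc(CCCC(F)(F)F)c4cc(Cl)ccc43)nc(N)c21`, differs from compound 3 in one place: trifluoromethyl in place of ethyl on a saturated chain carbon, three bonds along the chain from an aromatic carbon. Going by the values given here, the only measured step, a 1.1-fold lower number from compound 1 to compound 2 (0.06 log units; within the scatter), swaps fluorine on a phenyl and lies within the scatter, so it bears only loosely on a fluorinated chain. Among the compounds with values here, no measured pair sets a fluorinated chain against a plain one. The step of no change at the digits printed from compound 3 to compound 4 (within the scatter) is therefore expected to stay within the scatter. Compound 4 is estimated at 90000 nM, with a range from 30000 nM to 270000 nM.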

Compound 4, half-maximal effective concentration: 117000 nM
Estimate against measurement, compound 4: 1.3-fold (0.11 log units) below, and the stated range covers the measured number.
By their numbers in this assay, from the lowest: compounds 2 and 1 (each within the scatter of the next); then compounds 3 and 4 (each within the scatter of the next).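

In this assay the swap of ethyl for trifluoromethyl gives a 1.3-fold higher number from compound 3 to compound 4 (0.11 log units; within the scatter) and thus sets a fluorinated chain directly against a plain one for the first time among these compounds. At this place on the chain, the two numbers cannot be told apart, so fluorinating the chain end does not lift this series out of its weak range. Nothing shown here offers an explanation for this result.

From the compounds shown here alone, whether an amine or a carboxylic acid at the chain end would shift the number remains open. So does the effect of a longer chain.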